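Propyl for Isopropyl While Cytotoxicity Stays at the Limit

A few compounds are considered here, and "the series" means these few. Any claim that something is new, unique, unknown or untested is made for them only; others in the source may bear on it.

Compound 1 `CCOC(=O)CCCCCOc1cccc(CNC(C)C)c1` and compound 2 `CCOC(=O)CCCCCOc1ccc(CNC(C)C)cc1` are built from the same atoms joined differently; the difference between the two cores is not broken down here. In an ADME assay on BJ cells (Homo sapiens) for cytotoxicity, read by CellTiter-Glo and resazurin assay, with a stated time of 72 h (on this read-out higher numbers stand for an effect only at larger amounts of compound and lower numbers for an effect already at smaller amounts), compound 1 gives only a limit of the assay, > 26000 nM. In this assay compound 2 likewise gives only a limit, > 26000 nM. Compound 3 `CCCNCc1cccc(OCCCCCC(=O)OCC)c1` differs from compound 1 by one change, (propyl in place of isopropyl on an amine nitrogen). In this assay compound 3 also gives a limit, > 26000 nM. Among the measured compounds shown here, the step that the two limits leave unreadable from compound 1 to compound 3 is therefore left unreadable, since both ends sit at the limit, as the limit of > 26000 nM in this assay, at which 3 of the 3 values shown sit, shows for every value so far.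

Compound 4 `CCCNCc1ccc(OCCCCCC(=O)OCC)cc1` has not yet been measured. It carries the same change, (propyl in place of isopropyl on an amine nitrogen), at a place described in the same words. Because the earlier step that the two limits leave unreadable from compound 1 to compound 3 stayed at the limit on both sides, the step from compound 2 to compound 4 is expected to be of the same kind, a step that the limit leaves unreadable from compound 2 to compound 4. In this assay compound 4 is expected to give 40000 nM, most likely again only a limit, with a range from 20000 nM to 100000 nM.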

Compound 4, half-maximal effective concentration: > 26000 nM
Compound 4 gave a limit, no number (the forecaster's own chance of this, stated with the estimate: 85%); the middle value is on the limit's open side.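

Compound 4, like compound 2, gives only a limit in this assay, so no step from compound 2 to compound 4 can be read, and the size of the change stays unknown: the limit of > 26000 nM in this assay, at which 4 of the 4 values shown sit.

The compounds shown leave open at what amount any of them would harm these cells, and whether propyl in place of isopropyl makes any difference to cytotoxicity.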